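Propylamino for methylpiperazinyl on a shared core

The source may hold more compounds than are shown below. What is called first, only, known or untested is meant among the compounds shown, and "the series" means these compounds.

Compound 1 `Cc1ccc2nc(N3CCNC(C)C3)nc(NCc3ccc(C(=O)NC4CCN(Cc5ccc(F)cc5)CC4)cc3)c2c1` gives 1000 nM in a functional assay on SW480 cells (Homo sapiens) for inhibition, read by luminescence and resazurin assay, with a stated time of 3 days; a lower number here means a stronger inhibitor, a higher number a weaker inhibitor; compound 2 `CNc1nc(NCc2ccc(NS(=O)(=O)c3ccc(C)cc3)cc2)c2ccccc2n1` gives 4900 nM in the same assay.

Compound 1 holds the lowest number of the two, with compound 2 beyond the scatter. Compound 3 `CCCNc1nc(NCc2ccc(C(=O)NC3CCN(Cc4ccc(F)cc4)CC3)cc2)c2cc(C)ccc2n1` is unmeasured; it carries propylamino in place of 3-methylpiperazin-1-yl on an aromatic carbon. Compound 2 also bears an amino group at this position, yet it differs from compound 1 elsewhere, so the two values give no clean guide. A modest weakening from compound 1 is expected in this assay, a 2.0-fold higher number from compound 1 to compound 3 (0.30 log units; within the scatter). Compound 3 is estimated at 2000 nM, with a range from 700 nM to 6000 nM.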

Compound 3, half-maximal inhibitory concentration: 1100 nM
Compound 3: the middle estimate sits 1.8-fold (0.26 log units) above what was measured; the measured number falls inside the stated range.
By their numbers in this assay, from the lowest: compounds 1 and 3 (each within the scatter of the next); then compound 2.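

In this assay, propylamino in place of 3-methylpiperazin-1-yl on the shared core gives a 1.1-fold higher number from compound 1 to compound 3 (0.04 log units; within the scatter) and so stays within the scatter. At this aromatic carbon between two ring nitrogen atoms, the six-membered non-aromatic ring and its second nitrogen can therefore be replaced by an open chain without a step beyond the scatter. No measurement offered here accounts for this result.

The compounds shown leave open whether a longer chain such as hexylamino, a morpholine ring or a carboxylic acid at this position would read the same. They also leave open whether this holds on other cores.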